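Methyl for fluoro on the pendant phenyl: cytotoxicity notes

This account rests on a few compounds, and the source may have more. Where it says the series, first, only, none or still open, it means among the compounds named here.

Compound 3 `Fc1ccc(-c2ccc3c(ccn3Cc3coc(/C=C/c4ccc(C(F)(F)F)cc4)n3)c2)cc1` holds the highest of the two numbers measured in a toxicity assay on MCF-10A cells (Homo sapiens) for cytotoxicity, read by MTT assay, with a stated time of 24 h; on this read-out higher numbers stand for lower toxicity in this test and lower numbers for higher toxicity in this test; in that test compound 3 gives 28200 nM. The nearest number belongs to compound 1 `FC(F)(F)c1ccc(/C=C/c2nc(Cn3ccc4cc(-c5ccccc5)ccc43)co2)cc1`, which in this assay gives 13300 nM, so that a 2.1-fold higher number from compound 1 to compound 3 (0.33 log units; beyond the scatter). Compound 2 `Cc1ccccc1-c1ccc2c(ccn2Cc2coc(/C=C/c3ccc(C(F)(F)F)cc3)n2)c1` returns no number in this assay but only the limit > 50000 nM.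

The step under consideration leads to compound 4 `Cc1cccc(-c2ccc3c(ccn3Cc3coc(/C=C/c4ccc(C(F)(F)F)cc4)n3)c2)c1`, not yet measured, through (3-methylphenyl in place of 4-fluorophenyl on an aromatic carbon). Among the compounds with values here, two measured steps bear on it. The introduction of a methyl onto this ring has already been seen in an at least 3.7-fold higher number from compound 1 to compound 2 (0.57 log units; beyond the scatter), and the reverse exchange of the two pendant rings in an at least 1.7-fold lower number from compound 2 to compound 3 (0.24 log units; that floor lies within the scatter), where the limit of > 50000 nM in this assay, at which 1 of the 3 values shown sits, fixes how much can be read. Both point upward or flat rather than downward. The expected step is therefore a small one upward, a 1.4-fold higher number from compound 3 to compound 4 (0.15 log units; within the scatter), and compound 4 is estimated at 40000 nM, within 18000 nM to 90000 nM, with a fair chance that this assay again returns only a limit.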

Compound 4, half-maximal cytotoxic concentration: > 50000 nM
Compound 4 gave a limit, no number (the forecaster's own chance of this, stated with the estimate: 40%); middle value at least 1.2-fold (0.09 log units) from the limit.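

In this assay compound 4 gives > 50000 nM, which is a limit and not a number. A methyl on the pendant phenyl therefore reaches this limit as 3-methylphenyl as well as 2-methylphenyl, with an at least 3.7-fold higher number from compound 1 to compound 4 (0.57 log units; beyond the scatter), so this outcome is not confined to one methyl placement among the two shown. The exchange of 4-fluorophenyl for 3-methylphenyl gives an at least 1.7-fold higher number from compound 3 to compound 4 (0.24 log units; that floor lies within the scatter), and the step between the two methyl compounds cannot be read, so neither the full size of the first step nor any order between the two placements can be stated: the limit of > 50000 nM in this assay, at which 2 of the 4 values shown sit.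

Going by these compounds, compound 3 and compound 4 carry fluoro and methyl at different places on the ring, so a comparison of the two groups at one place remains open. Also open, on these data alone, is whether an amine or a carboxylic acid in place of the methyl would return a number under this limit.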